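Swapping the Benzyl Substituent in an Oxadiazole Sulfonamide

A few compounds are considered here, and "the series" means these few. Any claim that something is new, unique, unknown or untested is made for them only; others in the source may bear on it.

Two sulfonamides in this study have been measured in an assay on CHO cells for displacement of a labelled ligand from prostaglandin E2 receptor EP1 subtype (Homo sapiens); a lower number here means a stronger inhibitor, a higher number a weaker inhibitor. Compound 1 `CCc1ccccc1N(Cc1nnc(Cc2ccc(Cl)cc2)o1)S(=O)(=O)c1ccc(C)cc1` gives 398 nM in this assay. Compound 2 `Cc1ccc(S(=O)(=O)N(Cc2nnc(Cc3ccc(C(F)(F)F)cc3)o2)c2cccc(Cl)c2C)cc1` gives 50.1 nM in this assay. Compound 2 stands lowest of the two numbers; compound 1 is its nearest neighbour, and the gap between them is beyond the scatter. Going by the values given here, the two compounds differ in more than one place, so their values show only that compound 2 is the stronger inhibitor.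

Compound 3 `Cc1ccc(S(=O)(=O)N(Cc2nnc(Cc3cccc(Cl)c3)o2)c2cccc(Cl)c2C)cc1` has not yet been measured in this assay. It differs from compound 2 in a single place: 3-chlorophenyl in place of 4-(trifluoromethyl)phenyl on a saturated chain carbon bound to an aromatic carbon. Among the compounds with values here, no measured pair in this set isolates such a change, so the size and direction of the step cannot be read from the data. The same methyl-substituted benzenesulfonamide and the same oxadiazole core are kept in compound 3 as in compound 2, so the author expects compound 3 to remain a strong inhibitor, with a modest weakening: the expected step is a 2.0-fold higher number from compound 2 to compound 3 (0.30 log units; within the scatter). Compound 3 is therefore estimated at 100 nM in this assay, within a range of 40 nM to 300 nM.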

Compound 3, half-maximal inhibitory concentration: 158 nM
Compound 3: the middle estimate sits 1.6-fold (0.20 log units) below what was measured, within the range that was stated.
By their numbers in this assay, from the lowest: compound 2; then compound 3; then compound 1.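

In this assay, going by these compounds alone, a 3.2-fold higher number from compound 2 to compound 3 (0.50 log units; beyond the scatter) is the first change in this set that can be read on its own, and it shows that the group on this saturated chain carbon bound to an aromatic carbon affects the read-out even when the rest of the molecule stays the same. The change from 4-(trifluoromethyl)benzyl to 3-chlorobenzyl alters both the substituent and where it sits on the phenyl ring, so this single step cannot show how much of the difference belongs to each. Nothing measured here accounts for the size or direction of the step.

The compounds shown leave open how an unsubstituted benzyl, or a benzyl carrying a methoxy group, a nitrile, an amine or a carboxylic acid, would compare with the two groups seen at this position. They also leave open whether the step would keep its size and direction if another part of the molecule were changed, such as the methyl-substituted benzenesulfonamide.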